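This account rests on a few compounds, and the source may have more. Where it says the series, first, only, none or still open, it means among the compounds named here.

Compound 1 `CO[C@H]1C(=O)N2C(C(=O)C(C)(C)C)=C(C)[C@@H](OC=O)S(=O)(=O)C12` is the shortest-lived of the three measured compounds: in a physicochemical assay, at pH 7.4 (on this read-out lower numbers stand for a shorter-lived compound and higher numbers for a longer-lived compound), compound 1 gives < 0.5 h, which is a limit of the assay rather than a number. Compound 2 `CO[C@H]1C(=O)N2C(C(=O)C(C)(C)C)=C(C)[C@@H](OC(=O)CCC(=O)c3ccccc3)S(=O)(=O)C12` gives 13 h in this assay, and compound 3 `CO[C@H]1C(=O)N2C(C(=O)C(C)(C)C)=C(C)[C@@H](OC(=O)c3ccc4ccccc4c3)S(=O)(=O)C12` gives 33 h. Compound 4 `CO[C@H]1C(=O)N2C(C(=O)C(C)(C)C)=C(C)[C@@H](Sc3ccccn3)S(=O)(=O)C12` differs from compound 1 by (pyridin-2-yl)sulfanyl in place of formyloxy on a saturated ring carbon. The measured steps that bear on this change both start from compound 1: an at least 26-fold higher number from compound 1 to compound 2 (1.41 log units; beyond the scatter) and an at least 66-fold higher number from compound 1 to compound 3 (1.81 log units; beyond the scatter), with a further a 2.5-fold higher number from compound 2 to compound 3 (0.40 log units; beyond the scatter). Each replacement of the hydrogen on the carbonyl carbon by a larger group brought a large gain, and the change to compound 4 is expected to act in the same direction, so the step is estimated at an at least 40-fold higher number from compound 1 to compound 4 (1.60 log units; beyond the scatter). Compound 4 is therefore expected to give 20 h, between 3 h and 100 h.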

Compound 4, half-life: 24 h
For compound 4 the middle estimate is 1.2-fold (0.08 log units) below the measured one; low and high end bracket the measured number.
By their numbers in this assay, from the lowest: compounds 2, 4 and 3 (each within the scatter of the next, the first and the last beyond it). At a limit, below all of these: compound 1.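

The step of an at least 48-fold higher number from compound 1 to compound 4 (1.68 log units; beyond the scatter) shows that the gain at this saturated ring carbon does not depend on keeping a carbonyl there: the whole formyloxy group can leave, and compound 4 stands within the scatter of compound 2 and of compound 3. Compound 1 gives < 0.5 h, which is a limit, so the true size of this step stays unknown: the limit of < 0.5 h in this assay, at which 1 of the 4 values shown sits.

As far as these compounds go, whether the sulfur link or the pyridine ring carries the gain stays open. So does how a phenylsulfanyl group, a methylsulfanyl group or an amine would fare on this carbon.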